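The compounds below may be only part of what the source reports. "The series", "measured", "known", "first", "only" and "open" are said of these compounds alone.

Working notes on the trimethoxyphenyl series, all runs in a functional assay on MGC-803 cells (Homo sapiens) for inhibition, read by MTT assay, with a stated time of 48 h; a higher number here means a weaker inhibitor, a lower number a stronger inhibitor.

Compound 1 `COc1cc(N(Cc2ccc(F)cc2)S(=O)(=O)c2ccc(C)cc2)cc(OC)c1OC` gives 3750 nM in this assay. Compound 2 `COc1cc(N(Cc2ccccc2)S(=O)(=O)c2ccc(C)cc2)cc(OC)c1OC` gives 3570 nM in this assay. The two differ by fluoro in place of hydrogen on an aromatic carbon, and that step reads a 1.1-fold higher number from compound 2 to compound 1 (0.02 log units; within the scatter), so the fluoro on the benzyl ring leaves the value where it was.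

Compound 3 `COc1cc(N(Cc2nc3ccccc3[nH]2)C(=O)c2ccccc2)cc(OC)c1OC` carries a different core; the difference between the core of compound 3 and the core of compound 2 is not broken down here. In this assay compound 3 gives only a limit, > 50000 nM, not a number. This is the limit of > 50000 nM in this assay, at which 1 of the 3 values shown sits.

Compound 4 `COc1cc(N(Cc2nc3ccccc3[nH]2)C(=O)c2ccc(F)cc2)cc(OC)c1OC` has not yet been measured. It stands to compound 3 as compound 1 stands to compound 2: fluoro in place of hydrogen on an aromatic carbon. The place is the same in both pairs, an aromatic carbon of a six-membered aromatic ring of carbon only, para to a large group; one bond further out the change reads benzyl to 4-fluorobenzyl in the first pair and benzoyl to (4-fluorophenyl)carbonyl in the second, so it is the same kind of change on a different arm.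

The step from compound 3 to compound 4 is expected to be about a step that the limit leaves unreadable from compound 3 to compound 4 in this assay, resting on the within-scatter step a 1.1-fold higher number from compound 2 to compound 1 (0.02 log units; within the scatter) and on compound 3 standing at a limit, > 50000 nM. Compound 4 is therefore expected near 60000 nM in this assay, somewhere between 25000 nM and 200000 nM, and most likely reported again only as a limit.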

Compound 4, half-maximal inhibitory concentration: 23600 nM
Estimate against measurement, compound 4: 2.5-fold (0.41 log units) above, and the stated range ends above it.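

In this assay, fluoro in place of hydrogen on an aromatic carbon gives an at least 2.1-fold lower number from compound 3 to compound 4 (0.32 log units; beyond the scatter), while the same kind of change on the other core gives a 1.1-fold higher number from compound 2 to compound 1 (0.02 log units; within the scatter). Set side by side, the two steps read: the same change on two cores in this assay, a 1.1-fold higher number (0.02 log units; within the scatter) from compound 2 to compound 1 and an at least 2.1-fold lower number (0.32 log units; beyond the scatter) from compound 3 to compound 4; the limit leaves it open whether they differ

So the change has a readable effect on the core of compound 3 but none beyond the scatter on the core of compound 2, and this series offers no evidence that a result on one core can simply be carried to the other. It does not show that the two steps truly differ, nor how large the step on the core of compound 3 is, and the fluoro also sits on a benzyl arm in one pair and a benzoyl arm in the other, so the comparison is of like changes on unlike arms; compound 3 is held only as a limit: the limit of > 50000 nM in this assay, at which 1 of the 4 values shown sits.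

The compounds shown leave open how a chloro, a methoxy or an amine at the same place on the benzoyl ring of compound 3 would read. They also leave open whether fluoro would give the same step if it sat on the same arm in both cores.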